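The compounds below may be only part of what the source reports. "The series", "measured", "known", "first", "only" and "open" are said of these compounds alone.

Compound 1 `O=C1COc2ccc(-c3[nH]c(-c4ccc(C(F)(F)F)cc4)nc3-c3ccccc3)cc2N1`: 95%
Compound 2 `O=C1COc2ccc(-c3nn(-c4ccc(F)cc4)cc3-c3ccccc3)cc2N1`: 64.4%
Compound 3 `COc1ccc(-n2cc(-c3ccccc3)c(-c3ccc4c(c3)NC(=O)CO4)n2)cc1`: 92.2%

These three compounds were measured in a functional assay on DLD-1 cells (Homo sapiens) for cytotoxicity, read by colorimetric assay and MTT assay, with a stated time of 3 days, tested at 1 uM; a lower number here means a stronger effect, a higher number a weaker effect of the compound at the concentration tested. Compound 1 gives 95%, the highest of the three numbers; compound 3 lies within the scatter of it, while compound 2 lies beyond the scatter below it. At the tested concentration compound 1 thus shows a weak effect. Compound 4 `O=C1COc2ccc(-c3[nH]c(-c4ccccc4)nc3-c3ccccc3)cc2N1` has not yet been measured. It differs from compound 1 in one place: hydrogen in place of trifluoromethyl on an aromatic carbon.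

Among the compounds with values here, only one measured step exists, a number 27.8 percentage points higher from compound 2 to compound 3 (beyond the scatter), and it concerns a different exchange on a different core, so it offers no guide to trading trifluoromethyl for hydrogen. Within the data shown here, no measured pair tests this change directly. Compound 1 already sits near the top of the scale, where a compound shows almost no effect, and a value much higher is hardly possible. The expected outcome is therefore no step beyond the scatter, a number 5 percentage points lower from compound 1 to compound 4 (within the scatter). Compound 4 is expected to remain a weak compound in this assay. The estimate for compound 4 is 90%, expected to fall between 70% and 105%.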

Compound 4, a percentage reported as activity, at one concentration (the size of the read-out at that concentration, not a potency): 98.2%
The estimate for compound 4 lay 8.2 percentage points below the measured number, within the range that was stated.
By their numbers in this assay, from the lowest: compound 2; then compounds 3, 1 and 4 (each within the scatter of the next).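

In this assay, within the data shown here, putting hydrogen in place of trifluoromethyl on this aromatic carbon gives a number 3.2 percentage points higher from compound 1 to compound 4 (within the scatter), and this is the first direct test of any change at this position. The exchange of 4-(trifluoromethyl)phenyl for phenyl therefore makes no readable difference here, so trifluoromethyl is not needed to keep the number where it stands. Both compounds sit at the weak end of the scale, however, so there is little effect to lose, and no measurement shown explains the flat result.

The compounds shown leave open whether an amine or a carboxylic acid on this same aromatic carbon would bring the number down, since only trifluoromethyl and hydrogen have been seen there on this core. They also leave open whether the exchange of fluoro for methoxy, seen only between compound 2 and compound 3 on a different core, would give a step of similar size on the core of compound 4.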